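Methyl on the Benzoyl Group of Compound 1

This account rests on a few compounds, and the source may have more. Where it says the series, first, only, none or still open, it means among the compounds named here.

In a functional assay on Ehrlich cells (Mus musculus) for cytotoxicity, read by LDH release, with a stated time of 48 h (a lower number here means a stronger inhibitor, a higher number a weaker inhibitor), compound 1 (`Cc1cc(C(=O)c2ccccc2)ccc1OCC(=O)Nc1nc(-c2ccccc2)cs1`) gives 24500 nM, and compound 2 (`O=C(COc1ccc(C(=O)c2ccccc2)cc1Br)Nc1nc(-c2ccccc2)cs1`) gives 46400 nM. For the measured compounds named here, these are the only two measured values, and they stand within the scatter of each other: a 1.9-fold higher number from compound 1 to compound 2 (0.28 log units; within the scatter). Compound 1 therefore has a single close neighbour and no clear rank.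

Compound 3 (`Cc1cc(C(=O)c2ccccc2C)ccc1OCC(=O)Nc1nc(-c2ccccc2)cs1`) departs from compound 1 by methyl in place of hydrogen on an aromatic carbon. In words, this is methyl in place of hydrogen on an aromatic carbon, ortho to a large group, so that benzoyl becomes (2-methylphenyl)carbonyl. Going by the values given here, no measured step covers this change. Among the compounds with values here, the one available step, from compound 1 to compound 2, also concerns a methyl group, but it exchanges that group for bromo at a different place. Its size, a 1.9-fold higher number from compound 1 to compound 2 (0.28 log units; within the scatter), is only weak guidance, yet it offers no reason to expect a large shift. In this assay, going by these compounds, no step beyond the scatter is therefore expected, and the direction stays open. The estimate amounts to an expected 1.1-fold higher number from compound 1 to compound 3 (0.06 log units; within the scatter). For compound 3 the expected value is 28000 nM, with an estimated range of 12000 nM to 65000 nM.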

Compound 3, half-maximal inhibitory concentration: 26400 nM
Compound 3: middle estimate off by 1.1-fold (0.03 log units), on the high side, within the range that was stated.
By their numbers in this assay, from the lowest: compounds 1, 3 and 2 (each within the scatter of the next).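

At this place on the phenyl of the benzoyl group, this assay registers no step beyond the scatter when methyl replaces hydrogen on an aromatic carbon ortho to a large group, turning phenyl into 2-methylphenyl: a 1.1-fold higher number from compound 1 to compound 3 (0.03 log units; within the scatter). For the compounds shown here, the earlier pair spoke only to a different place on the molecule, where bromo stands in place of methyl with a 1.9-fold higher number from compound 1 to compound 2 (0.28 log units; within the scatter), so this is the first reading of any change on the benzoyl phenyl, and it shows that adding this one carbon leaves the number within the scatter of compound 1. Nothing in the available data gives a measured property or other direct evidence that bears on this result.

Going by these compounds alone, whether this holds only for methyl stays open, as a carboxylic acid, an amine or a longer chain at the same place could behave differently from the one small group seen here. No step shown lies beyond the scatter in this series, and which kind of change to the core of compound 1 would produce such a step remains an open question.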